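Trifluoromethyl for trifluoromethoxy across two cores

The source may hold more compounds than are shown below. What is called first, only, known or untested is meant among the compounds shown, and "the series" means these compounds.

Compound 1 `CCN(CC)c1ccc2nc(-c3ccccc3OC(F)(F)F)[nH]c(=O)c2c1` and compound 2 `CCN(CC)c1ccc2nc(-c3ccccc3C(F)(F)F)[nH]c(=O)c2c1` share one core; compound 3 `Cc1ccc2c(=O)[nH]c(-c3cccc(OC(F)(F)F)c3)nc2c1` and the unmeasured compound 4 `Cc1ccc2c(=O)[nH]c(-c3cccc(C(F)(F)F)c3)nc2c1` share another. The difference between the two cores is not broken down here.

In a functional assay on T47D cells (Homo sapiens) for cytotoxicity, read by MTT assay, with a stated time of 2 days (on this read-out lower numbers stand for stronger inhibition and higher numbers for weaker inhibition), compound 1 gives 1670 nM. Compound 2 gives 2550 nM in this assay. The change between them is trifluoromethyl in place of trifluoromethoxy on an aromatic carbon, and it made a 1.5-fold higher number from compound 1 to compound 2 (0.18 log units; within the scatter), so the two values cannot be told apart.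

Compound 3 reaches only a limit of this assay, > 50000 nM; this is the limit of > 50000 nM in this assay, at which 1 of the 3 values shown sits.

The change from compound 3 to compound 4 is trifluoromethyl in place of trifluoromethoxy on an aromatic carbon. Within the data shown here, it is the same kind of change as the one from compound 1 to compound 2, not the same: in the first pair the place is ortho to a large group, in the second pair it is meta to a large group, and the cores differ. Where this kind of change has been measured it moved the number within the scatter, and compound 3 already sits at the limit with > 50000 nM, so the step from compound 3 to compound 4 is expected to be about a step that the limit leaves unreadable from compound 3 to compound 4, most probably again ending at a limit rather than a number. Compound 4 is therefore estimated at 60000 nM, within a range from 20000 nM to 200000 nM, in this assay.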

Compound 4, half-maximal inhibitory concentration: > 50000 nM
Compound 4: only a limit was reported; the forecaster's own chance of this, stated with the estimate: 75%; the middle value is on the limit's open side.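

In this assay compound 3 and compound 4 both reach only a limit, so the step between them cannot be read: the limit of > 50000 nM in this assay, at which 2 of the 4 values shown sit.

The compounds shown leave open whether trifluoromethyl in place of trifluoromethoxy, meta to a large group, changes the number at all on the core of compound 3, and where either compound would fall beyond the limit.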